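From Amide to Urea: Compound 3 Awaits Its Number

A few compounds are considered here, and "the series" means these few. Any claim that something is new, unique, unknown or untested is made for them only; others in the source may bear on it.

Compound 1 `COc1ccccc1C(=O)Nc1cnn(Cc2c(C)noc2C)c1`: 1900 nM
Compound 2 `COc1cccc(C(=O)Nc2cnn(Cc3c(C)noc3C)c2)c1`: 700 nM

Two measured compounds share one core and differ only in the aryl group attached to the carbonyl carbon. In a functional assay on cells for antagonist activity at taste receptor type 2 member 8 (Homo sapiens), read by FLIPR and calcium flux, with a stated time of 100 s (on this read-out lower numbers stand for stronger inhibition and higher numbers for weaker inhibition), compound 1 gives 1900 nM. In this assay compound 2 gives 700 nM. Within the data shown here, the single measured step, a 2.7-fold lower number from compound 1 to compound 2 (0.43 log units; beyond the scatter), exchanges 2-methoxyphenyl for 3-methoxyphenyl. On the numbers available, compound 2 stands with the lowest of the two, its nearest neighbour being compound 1 through that step.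

Compound 3 `Cc1noc(C)c1Cn1cc(NC(=O)Nc2ccccc2)cn1` differs from compound 2 by anilino in place of 3-methoxyphenyl on a carbonyl carbon. Among the measured compounds shown here, no measured step touches the carbonyl-bearing group in this way: the step of a 2.7-fold lower number from compound 1 to compound 2 (0.43 log units; beyond the scatter) keeps an aryl ring on the carbonyl carbon and alters only the methoxy pattern, so it offers little guidance here, and the expectation rests on the absence of any comparable precedent. Compound 3 is expected to give about 1500 nM in this assay, with a range from 400 nM to 6000 nM. The expected step is a 2.1-fold higher number from compound 2 to compound 3 (0.33 log units; beyond the scatter), a weakening whose direction is uncertain.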

Compound 3, half-maximal inhibitory concentration: 2000 nM
Compound 3: the middle estimate sits 1.3-fold (0.12 log units) below what was measured; the range from low to high includes it.
By their numbers in this assay, from the lowest: compound 2; then compounds 1 and 3 (each within the scatter of the next).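

In this assay, anilino in place of 3-methoxyphenyl on a carbonyl carbon gives a 2.9-fold higher number from compound 2 to compound 3 (0.46 log units; beyond the scatter) and so shows, as the methoxy shift alone could not, that this position also responds when a nitrogen-linked ring replaces the ring bonded directly to the carbonyl carbon. Set against the 2-methoxyphenyl group, the same anilino group gives a 1.1-fold higher number from compound 1 to compound 3 (0.02 log units; within the scatter) and leaves compound 1 and compound 3 indistinguishable, while compound 2 remains the strongest of the three, its steps to both others lying beyond the scatter. Nothing available explains why the anilino group matches 2-methoxyphenyl on this read-out and not 3-methoxyphenyl.

The compounds shown leave open whether 3-methoxyanilino on the carbonyl carbon would bring the urea series back to the level of compound 2, which would separate the effect of the methoxy group from that of the added amide-type nitrogen. They also leave open how a phenoxy group, a benzylamino group or a simple methylamino group would behave at this position, and so whether the ring itself is needed there.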